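The source may hold more compounds than are shown below. What is called first, only, known or untested is meant among the compounds shown, and "the series" means these compounds.

Three compounds share one core and differ only in the group attached to the amide. Compound 1 `Cn1c(-c2ccc(NC(=O)CCl)cc2)nc(-c2ccccc2)c1-c1ccccc1` carries a chloro there and in a functional assay on MCF7 cells (Homo sapiens) for cytotoxicity, read by MTT assay, with a stated time of 24 h, tested at 0.64 ug/mL (on this read-out higher numbers stand for a stronger effect at the one concentration tested and lower numbers for a weaker effect), compound 1 gives 3.4%. Compound 2 `Cn1c(-c2ccc(NC(=O)CSc3nc4ccccc4o3)cc2)nc(-c2ccccc2)c1-c1ccccc1` carries a (1,3-benzoxazol-2-yl)sulfanyl and in this assay compound 2 gives 18.7%, the highest of the three numbers. Compound 3 `Cn1c(-c2ccc(NC(=O)CSc3nc4cc(Cl)ccc4o3)cc2)nc(-c2ccccc2)c1-c1ccccc1` carries a (5-chloro-1,3-benzoxazol-2-yl)sulfanyl and in this assay compound 3 gives 2.4%.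

Compound 4 `Cn1nnnc1SCC(=O)Nc1ccc(-c2nc(-c3ccccc3)c(-c3ccccc3)n2C)cc1` is not yet measured. Its change from compound 2 is 1-methyl-1H-tetrazol-5-yl in place of 1,3-benzoxazol-2-yl on a sulfur. Among the measured compounds shown here, no measured step swaps one ring for another on the sulfur, so the nearest guides are a number 15.3 percentage points higher from compound 1 to compound 2 (beyond the scatter) and a number 16.3 percentage points lower from compound 2 to compound 3 (beyond the scatter), both of which show that what sits on the sulfur moves the number by a modest amount in either direction. Since the 1,3-benzoxazol-2-yl that raised the number in compound 2 is removed, a step downward toward the level of compound 1 is expected, of about a number 11.7 percentage points lower from compound 2 to compound 4 (beyond the scatter). Compound 4 is therefore estimated at 7% in this assay, within a range from 0% to 20%.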

Compound 4, a percentage reported as activity, at one concentration (the size of the read-out at that concentration, not a potency): 21.9%
Beside the measured number, compound 4's estimate is 14.9 percentage points below it; the whole stated range lies below it.
By their numbers in this assay, from the lowest: compounds 3 and 1 (each within the scatter of the next); then compounds 2 and 4 (each within the scatter of the next).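

On the sulfur, 1-methyl-1H-tetrazol-5-yl takes the place of 1,3-benzoxazol-2-yl with no step beyond the usual scatter in this assay (a number 3.2 percentage points higher from compound 2 to compound 4 (within the scatter)), although the entering group has one ring where the leaving group has two. For these two groups, then, the six-membered ring of carbon only is not needed to keep the number at this level. The rise over the chloro now appears with a second group (a number 18.5 percentage points higher from compound 1 to compound 4 (beyond the scatter)), while the 5-chloro-1,3-benzoxazol-2-yl remains the exception among the groups on the sulfur (a number 19.5 percentage points higher from compound 3 to compound 4 (beyond the scatter)).

Still open, going by these compounds, is how a plain phenyl or a carboxylic acid on the sulfur would read, and whether these differences hold at other concentrations. No measurement shown here explains the numbers.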